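The compounds below may be only part of what the source reports. "The series", "measured", "known", "first", "only" and "open" are said of these compounds alone.

In a functional assay on NCI-H520 cells (Homo sapiens) for cytotoxicity (on this read-out higher numbers stand for weaker inhibition of growth and lower numbers for stronger inhibition of growth), compound 3 `CSc1ccc(C2=C(c3ccc(O)c(O)c3)C(=O)N3CCCC3C2)cc1` gives 60000 nM. Compound 2 `COc1ccc(C2=C(c3ccc(SC)cc3)CC3CCCN3C2=O)cc1OC` gives 2000 nM, so compound 3 stands at the higher of these two numbers, and the gap lies beyond the scatter. Compound 1 `COc1ccc(C2=C(c3cc(OC)c(OC)c(OC)c3)CC3CCCN3C2=O)cc1O` is reported only as a limit of the assay, > 100000 nM, and not as an exact number.

Compound 4 `CSc1ccc(C2=C(c3ccc(SC)cc3)C(=O)N3CCCC3C2)cc1` is compound 3 with 4-(methylsulfanyl)phenyl in place of 3,4-dihydroxyphenyl on a double-bonded ring carbon. The new group matches the 4-(methylsulfanyl)phenyl already present on the neighbouring ring atom. Among the measured compounds shown here, no two measured compounds differ in only one place, so this step has no direct precedent and any forecast is loose.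

The best guide is compound 2 at 2000 nM, which, like compound 4, has no 3,4-dihydroxyphenyl group. A sizeable drop beyond the scatter, towards stronger inhibition of growth, is therefore expected, and the expected step is a 12-fold lower number from compound 3 to compound 4 (1.08 log units; beyond the scatter). For compound 4, the estimated value is 5000 nM, with an expected range of 800 nM to 30000 nM.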

Compound 4, concentration for 50% growth inhibition: 15000 nM
Compound 4: the middle estimate sits 3.0-fold (0.48 log units) below what was measured; measured number inside the range.
By their numbers in this assay, from the lowest: compound 2; then compound 4; then compound 3. At a limit, above all of these: compound 1.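

In this assay, among the compounds shown here, the change of 3,4-dihydroxyphenyl to 4-(methylsulfanyl)phenyl on this double-bonded ring carbon gives a 4.0-fold lower number from compound 3 to compound 4 (0.60 log units; beyond the scatter), the first comparison here in which only one place differs. This shows that the group on this carbon affects growth inhibition, and that the hydroxyl groups of 3,4-dihydroxyphenyl are not needed for compound 4 to inhibit growth more strongly. Compound 3 and compound 4 both have exact numbers, so this step can be read, unlike a comparison with a value at the limit: the limit of > 100000 nM in this assay, at which 1 of the 4 values shown sits.

Because one whole group replaces another, the loss of the hydroxyl groups cannot be separated from the gain of the methylsulfanyl group. Going by these compounds, how a plain phenyl or a 4-aminophenyl group would behave on this carbon remains open.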